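Removing a phenyl from a spiro-fused cytotoxic scaffold

The source may report more compounds than this note shows. Statements on the series, on what has been measured and on what is new or still open speak of the compounds shown alone.

Within the data shown here, of the two measured compounds, compound 1 `CC(C)C[C@]1(O)NC(=O)[C@]2(OC(Cc3ccccc3)=CC2=O)[C@H]1O` stands highest in a functional assay on HL-60 cells (Homo sapiens) for cytotoxicity, read by WST assay, with a stated time of 48 h (a lower number here means a stronger inhibitor, a higher number a weaker inhibitor), giving 28000 nM, while compound 2 `CC1=CC(=O)[C@]2(O[C@@H]2C(=O)CC(C)C)C(=O)N1` gives 1700 nM in this assay, a gap described as beyond the scatter; the two share no single-point step. Compound 3 `CC1=CC(=O)[C@]2(O1)C(=O)N[C@@](O)(CC(C)C)[C@@H]2O` has not been measured. It differs from compound 1 by hydrogen in place of phenyl on a saturated chain carbon bound to a double-bonded ring carbon, the benzyl becoming a methyl. Among the measured compounds shown here, with no measured step of this kind, a modest movement toward a lower number is expected, a 1.9-fold lower number from compound 1 to compound 3 (0.27 log units; within the scatter), not far beyond the scatter. Compound 3 is therefore estimated at 15000 nM, within 4000 nM to 50000 nM.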

Compound 3, half-maximal inhibitory concentration: > 50000 nM
Compound 3 was reported as a limit; the forecaster's own chance of this, stated with the estimate: 15%; middle value at least 3.3-fold (0.52 log units) from the limit.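

Shortening benzyl to methyl at this carbon brought no movement toward a lower number in this assay; the change reads an at least 1.7-fold higher number from compound 1 to compound 3 (0.25 log units; that floor lies within the scatter). Compound 3 stands at a limit and not at a number, so only a floor of that step is known: the limit of > 50000 nM in this assay, at which 1 of the 3 values shown sits. At this position, then, the phenyl does not hold compound 1 back, though how much it contributes stays unsized. Still open, going by these compounds, is what a group of intermediate length, such as an ethyl, would do here, or a phenyl carrying a fluorine or an amine.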